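Chloro to trifluoromethoxy: working notes on compound 4

The compounds below may be only part of what the source reports. "The series", "measured", "known", "first", "only" and "open" are said of these compounds alone.

In a functional assay on HCT-116 cells (Homo sapiens) for antiproliferative activity, read by MTT assay, with a stated time of 72 h (a lower number here means a stronger inhibitor, a higher number a weaker inhibitor), compound 1 `O=C(CCc1cccc2c1B(O)OC2)Nc1cccc(-c2ccccc2)c1` gives 890 nM while compound 2 `O=C(CCc1cccc2c1B(O)OC2)Nc1cccc(-c2ccc(Cl)cc2)c1` gives 380 nM and compound 3 `COc1cc(OC)cc(-c2cccc(NC(=O)CCc3cccc4c3B(O)OC4)c2)c1` gives 53 nM as the lowest number. Compound 2 holds the middle place. Compound 4 `O=C(CCc1cccc2c1B(O)OC2)Nc1cccc(-c2ccc(OC(F)(F)F)cc2)c1` carries trifluoromethoxy in place of chloro on an aromatic carbon, para to a large group (trifluoromethoxy in place of chloro on an aromatic carbon). Chloro in place of hydrogen gave a modest step (a 2.3-fold lower number from compound 1 to compound 2 (0.37 log units; beyond the scatter)). 3,5-Dimethoxyphenyl gave a modest step from 4-chlorophenyl (a 7.2-fold lower number from compound 2 to compound 3 (0.86 log units; beyond the scatter)) and a large one from phenyl (a 17-fold lower number from compound 1 to compound 3 (1.23 log units; beyond the scatter)). Among the compounds with values here, no measured compound carries trifluoromethoxy, so no step beyond the scatter is expected in this assay in either direction. The expected change is small (a 1.1-fold higher number from compound 2 to compound 4 (0.02 log units; within the scatter)). The estimate for compound 4 is 400 nM (expected range 150 nM to 1000 nM).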

Compound 4, half-maximal inhibitory concentration: 730 nM
The estimate for compound 4 lay 1.8-fold (0.26 log units) below the measured number, within the range that was stated.
By their numbers in this assay, from the lowest: compound 3; then compounds 2, 4 and 1 (each within the scatter of the next, the first and the last beyond it).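

In this assay, trifluoromethoxy on this aromatic carbon gives a 1.9-fold higher number from compound 2 to compound 4 (0.28 log units; within the scatter) against chloro and a 1.2-fold lower number from compound 1 to compound 4 (0.09 log units; within the scatter) against hydrogen. Compound 4 therefore cannot be separated from either compound 2 or compound 1, although those two lie beyond the scatter of each other. At this place, a group of 5 heavy atoms is thus accommodated without a step beyond the scatter from either smaller substituent.

Open, on these data alone, is whether an amine or a carboxylic acid on the same carbon would give a step beyond the scatter. Nothing available bears on what lies behind these numbers.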